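The source may hold more compounds than are shown below. What is called first, only, known or untested is meant among the compounds shown, and "the series" means these compounds.

In an ADME assay on a cell-free system (plasma, Mus musculus) for metabolic stability, read by LC-MS, with a stated time of 60 min, tested at 10 uM (a higher number here means that more of the compound is left, a lower number that less of the compound is left), compound 1 (`CCC(OC(=O)N[C@@H](CCC(=O)C=[N+]=[N-])C(=O)OC)OC(=O)C(C)(C)C`) gives 0%, so none of it is detected at the end of the test. Compound 2 (`Cc1oc(=O)oc1COC(=O)N[C@@H](CCC(=O)C=[N+]=[N-])C(=O)OC(C)C`) gives 0%, which puts the two level. Compound 3 (`COC(=O)[C@H](CCC(=O)C=[N+]=[N-])NC(=O)OC(OC(=O)C(C)(C)C)C(C)C`) is still unmeasured. It differs from compound 1 by one small change, (methyl in place of hydrogen on a saturated chain carbon bound to two saturated chain carbons), which turns ethyl to isopropyl. Within the data shown here, no measured pair shows what such a change does in this assay, so the expected size is modest, with a number 3 percentage points higher from compound 1 to compound 3 (within the scatter) estimated to stay within the usual scatter. For compound 3 the estimated value is 3%, with an expected range from 0% to 15%.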

Compound 3, percent of the compound remaining: 0%
The estimate for compound 3 lay 3 percentage points above the measured number; low and high end bracket the measured number.
By their numbers in this assay, from the lowest: compounds 1, 2 and 3 (each within the scatter of the next).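

In this assay, methyl in place of hydrogen on a saturated chain carbon bound to two saturated chain carbons, which turns ethyl to isopropyl, now has its first reading (no change at the digits printed from compound 1 to compound 3 (within the scatter)). Neither compound is detected at the end of the test, so this reading cannot show whether the change alters how fast the compound is lost. Nothing measured here gives a reason for this result. Still open, going by these compounds, is whether a longer chain or a cyclohexyl group at this place would leave any compound detectable.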